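The source may hold more compounds than are shown below. What is called first, only, known or untested is meant among the compounds shown, and "the series" means these compounds.

In a functional assay (aorta) with Rattus norvegicus as the target (a higher number here means a weaker inhibitor, a lower number a stronger inhibitor), compound 1 `CC1(C)Oc2ccc(C#N)cc2[C@@H](NC(=O)Nc2ccccc2)[C@@H]1O` gives 800 nM, compound 2 `CC1(C)Oc2ccc(C#N)cc2[C@@H](NC(=O)c2ccccc2)[C@@H]1O` gives 30 nM and compound 3 `CC1(C)Oc2ccc(C#N)cc2[C@@H](NC(=O)Nc2cccnc2)[C@@H]1O` gives 500 nM. Compound 3 therefore sits level with compound 1, within the scatter, and well clear of compound 2, which carries the lowest number of the three. Compound 4 `CC1(C)Oc2ccc(C#N)cc2[C@@H](NC(=O)Nc2ccncc2)[C@@H]1O` differs from compound 3 in one place: pyridin-4-yl in place of pyridin-3-yl on an amide-type nitrogen. This puts pyridin-4-yl in place of pyridin-3-yl on an amide-type nitrogen.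

The closest evidence is the change on that same nitrogen from phenyl to pyridin-3-yl, which gave a 1.6-fold lower number from compound 1 to compound 3 (0.20 log units; within the scatter). The two large steps, a 27-fold lower number from compound 1 to compound 2 (1.43 log units; beyond the scatter) and a 17-fold higher number from compound 2 to compound 3 (1.22 log units; beyond the scatter), both replace the amino-linked group on the carbonyl carbon with phenyl or the reverse, so they do not bear on this swap. Among the compounds with values here, no measured pair compares the two pyridinyl groups directly. No step beyond the scatter is therefore expected in this assay. The expected step is no change at the digits printed from compound 3 to compound 4 (within the scatter). For compound 4 the estimate is 500 nM, with an expected range from 200 nM to 1200 nM.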

Compound 4, half-maximal inhibitory concentration: 8500 nM
Beside the measured number, compound 4's estimate is 17-fold (1.23 log units) below it; measured number above the stated range.
By their numbers in this assay, from the lowest: compound 2; then compounds 3 and 1 (each within the scatter of the next); then compound 4.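

In this assay this nitrogen proves sensitive to which pyridinyl group it carries: pyridin-4-yl in place of pyridin-3-yl gives a 17-fold higher number from compound 3 to compound 4 (1.23 log units; beyond the scatter), although the two groups have the same atoms. The earlier change from phenyl to pyridin-3-yl stayed within the scatter, whereas pyridin-4-yl in place of phenyl on this nitrogen gives an 11-fold higher number from compound 1 to compound 4 (1.03 log units; beyond the scatter), so the two pyridinyl groups do not behave alike here. The swap on the carbonyl carbon, (pyridin-4-yl)amino in place of phenyl, gives a 280-fold higher number from compound 2 to compound 4 (2.45 log units; beyond the scatter), the largest step in the set.

No measurement at hand accounts for the difference between the two pyridinyl groups. Open questions are where pyridin-2-yl on this nitrogen would fall, and whether pyridin-4-yl attached directly to the carbonyl carbon, with no amino link, would stay close to compound 2.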